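Swapping the thiazoline tail for a methylpiperazine on compound 2

This account rests on a few compounds, and the source may have more. Where it says the series, first, only, none or still open, it means among the compounds named here.

Within the data shown here, compound 2 `Cn1c(-c2ccc(NC(=O)CSC3=NCCS3)cc2)nc(-c2ccccc2)c1-c1ccccc1` gives 30.4% in a functional assay on HT-29 cells (Homo sapiens) for cytotoxicity, read by MTT assay, with a stated time of 24 h, tested at 1.6 ug/mL (on this read-out higher numbers stand for a stronger effect at the one concentration tested and lower numbers for a weaker effect), the highest of the two numbers so far; compound 1 `Cn1c(-c2ccc(NC(=O)CCl)cc2)nc(-c2ccccc2)c1-c1ccccc1` gives 14.4%. Among the measured compounds shown here, the one measured step, a number 16 percentage points higher from compound 1 to compound 2 (beyond the scatter), moved toward compound 2. Compound 3 `CN1CCN(CC(=O)Nc2ccc(-c3nc(-c4ccccc4)c(-c4ccccc4)n3C)cc2)CC1` differs from compound 2 by a group of 7 heavy atoms (5 carbon, 2 nitrogen; one six-membered non-aromatic ring with 2 hetero atoms) in place of a group of 6 heavy atoms (3 carbon, 1 nitrogen, 2 sulfur; one five-membered non-aromatic ring with 2 hetero atoms), on a saturated chain carbon bound to a carbonyl carbon. For the measured compounds named here, no measured step covers this exchange; the step from compound 1 only shows that the chain end matters. Compound 3 is therefore expected to show a number 8.4 percentage points lower from compound 2 to compound 3 (within the scatter), within the scatter, and its estimated value is 22%, ranging from 6% to 40%.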

Compound 3, a percentage reported as activity, at one concentration (the size of the read-out at that concentration, not a potency): 27.4%
Estimate against measurement, compound 3: 5.4 percentage points below, within the range that was stated.
By their numbers in this assay, from the lowest: compound 1; then compounds 3 and 2 (each within the scatter of the next).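

With a number 3 percentage points lower from compound 2 to compound 3 (within the scatter) in this assay, the 4-methylpiperazin-1-yl group and the thiazoline tail of compound 2 cannot be told apart at this saturated chain carbon. With a number 13 percentage points higher from compound 1 to compound 3 (beyond the scatter) as well, a second, different group in place of chloro now gives a number beyond the scatter of the chloro compound, which one step alone could not show. Nothing available explains this. As far as these compounds go, it remains open how an open-chain amine such as dimethylamino or a carboxylic acid would read on this carbon, and whether a longer chain carrying the 4-methylpiperazin-1-yl group would change the number.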